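Selenium-linked bis-nitrothiophene amidines: benzyl to methyl

A few compounds are considered here, and "the series" means these few. Any claim that something is new, unique, unknown or untested is made for them only; others in the source may bear on it.

Going by the values given here, compound 2 `O=C(/N=C(/NC(=O)c1csc([N+](=O)[O-])c1)[Se]Cc1ccccc1)c1csc([N+](=O)[O-])c1` is the only member of the set with a number in a functional assay on MCF7 cells (Homo sapiens) for cytotoxicity, read by MTT assay, with a stated time of 72 h (on this read-out lower numbers stand for higher toxicity in this test and higher numbers for lower toxicity in this test), where compound 2 gives 83800 nM. Compound 1 `CS/C(=N\C(=O)c1csc([N+](=O)[O-])c1)NC(=O)c1csc([N+](=O)[O-])c1` sits at a limit of this assay, > 100000 nM. Among the compounds with values here, the step of an at least 1.1-fold lower number from compound 1 to compound 2 (0.07 log units; that floor lies within the scatter) is the one measured step that bears on the change at hand. Compound 3 `C[Se]/C(=N\C(=O)c1csc([N+](=O)[O-])c1)NC(=O)c1csc([N+](=O)[O-])c1` differs from compound 2 by hydrogen in place of phenyl on a saturated chain carbon bound to a selenium atom. Since that step lies within the scatter, no step beyond the scatter is expected. The expected step is a 1.2-fold higher number from compound 2 to compound 3 (0.08 log units; within the scatter). Compound 3 is estimated at 100000 nM, within 45000 nM to 300000 nM, with a fair chance of a result at the limit of > 100000 nM in this assay, at which 1 of the 2 values shown sits.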

Compound 3, concentration lethal to 50% of the cells: > 100000 nM
Compound 3 gave a limit, no number; the forecaster's own chance of this, stated with the estimate: 55%; the middle value sits exactly at the limit.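

In this assay compound 3 gives > 100000 nM which is a limit and not a number. Benzyl to methyl on selenium gives an at least 1.1-fold higher number from compound 2 to compound 3 (0.07 log units; that floor lies within the scatter) so losing the phenyl at this place produces no step beyond the scatter. The limit now holds for most of the set: the limit of > 100000 nM in this assay, at which 2 of the 3 values shown sit.

Going by these compounds, the step from compound 1 to compound 3 cannot be read, so the exchange of sulfur for selenium with methyl in place stays open. Also open, on these data alone, is whether an amine or a longer chain, on a saturated chain carbon bound to a selenium atom, would give a readable number.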